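The compounds below may be only part of what the source reports. "The series", "measured", "known", "first", "only" and "open" are said of these compounds alone.

Three compounds share one core, which carries an amide formed from a chlorinated cinnamic fragment, and differ only in the group on one aromatic carbon of that core. Compound 1 `Cc1nc(N(C)C2CCCC2)nc2ccc(NC(=O)/C=C/c3ccc(Cl)cc3)cc12` bears a cyclopentyl(methyl)amino group there, and in a functional assay on CHO-K1 cells for antagonist activity at melanin-concentrating hormone receptor 1 (Homo sapiens), read by inositol phosphate accumulation, with stated times of 10 min and 45 min (on this read-out lower numbers stand for stronger inhibition and higher numbers for weaker inhibition), compound 1 gives 57 nM. Compound 2 `CCCC1(O)CCN(c2nc(C)c3cc(NC(=O)/C=C/c4ccc(Cl)cc4)ccc3n2)CC1` carries a 4-hydroxy-4-propylpiperidin-1-yl group instead; in this assay compound 2 gives 91 nM, a change of a 1.6-fold higher number from compound 1 to compound 2 (0.20 log units; within the scatter). Compound 3 `Cc1nc(N2CCC(O)(C3CCC3)CC2)nc2ccc(NC(=O)/C=C/c3ccc(Cl)cc3)cc12` has a 4-cyclobutyl-4-hydroxypiperidin-1-yl group, and in this assay compound 3 gives 54 nM. Compound 3 stands nearest to compound 1, with a 1.1-fold lower number from compound 1 to compound 3 (0.02 log units; within the scatter), and furthest from compound 2, with a 1.7-fold lower number from compound 2 to compound 3 (0.23 log units; within the scatter), so all three sit together within the scatter.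

Compound 4 `Cc1nc(N2CCC(O)CC2)nc2ccc(NC(=O)/C=C/c3ccc(Cl)cc3)cc12` strips the cyclobutyl group from compound 3: hydrogen in place of cyclobutyl on a saturated ring carbon. Among the measured compounds shown here, no measured pair covers the loss of this group altogether. The closest comparison is the exchange of propyl for cyclobutyl at the same carbon, a 1.7-fold lower number from compound 2 to compound 3 (0.23 log units; within the scatter), and the broader swaps among compounds 1, 2 and 3 also moved the number little. Every change tried at this part of the molecule has left the value in a narrow band, so the step of a 2.0-fold higher number from compound 3 to compound 4 (0.31 log units; beyond the scatter) is expected to be small, leaning if anything toward a somewhat higher number, with wide uncertainty. Compound 4 is therefore estimated to give 110 nM, in a range from 40 nM to 320 nM.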

Compound 4, half-maximal inhibitory concentration: 73 nM
For compound 4 the middle estimate is 1.5-fold (0.18 log units) above the measured one, within the range that was stated.
By their numbers in this assay, from the lowest: compounds 3, 1, 4 and 2 (each within the scatter of the next).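

The new result shows that this saturated ring carbon need not carry any carbon group at all: in this assay, hydrogen in place of cyclobutyl gives a 1.4-fold higher number from compound 3 to compound 4 (0.13 log units; within the scatter) and hydrogen in place of propyl gives a 1.2-fold lower number from compound 2 to compound 4 (0.10 log units; within the scatter). Until now, cyclobutyl and propyl could only be compared with each other, whereas these two steps, both within the scatter, give no sign that either group is needed for the value or harms it. The plain 4-hydroxypiperidin-1-yl group also stays within the scatter of the cyclopentyl(methyl)amino group, with a 1.3-fold higher number from compound 1 to compound 4 (0.11 log units; within the scatter) as the step, and nothing in the data explains why this part of the molecule tolerates such different groups.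

The compounds shown leave open whether the hydroxyl group on this ring carbon matters, as no pair here swaps it for hydrogen, an amine or a carboxylic acid while the rest of the piperidine stays the same. They also leave open how far the tolerance extends, for instance to a phenyl ring or a longer chain such as hexyl in place of the cyclobutyl group.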